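Limits at the thiazolyl position, and a pyrrolidinyl swap

The source may hold more compounds than are shown below. What is called first, only, known or untested is meant among the compounds shown, and "the series" means these compounds.

In a toxicity assay on NIH3T3 cells (Mus musculus) for cytotoxicity, read by resazurin assay (on this read-out lower numbers stand for an effect already at smaller amounts and higher numbers for an effect only at larger amounts of compound), the measured compounds stand as follows:
- compound 1 `CNC(=O)c1ccc(NCc2cncn2Cc2ccc(-c3ccccc3)cc2)cc1-c1ccccc1` gives > 1000 nM as a limit
- compound 2 `CCOC(=O)c1ccc(NCc2cncn2Cc2ccc(-c3ccccc3)cc2)cc1-c1ccccc1` gives > 10000 nM as a limit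
- compound 3 `c1ccc(-c2ccc(Cn3cncc3CNc3ccc(-c4cncs4)c(-c4ccccc4)c3)cc2)cc1` gives > 1000 nM as a limit

Compound 3 has no exact number, only the limit of > 1000 nM in this assay, at which 2 of the 3 values shown sit, in the series. Compound 4 `c1ccc(-c2ccc(Cn3cncc3CNc3ccc(N4CCCC4)c(-c4ccccc4)c3)cc2)cc1` carries pyrrolidin-1-yl in place of 1,3-thiazol-5-yl on an aromatic carbon at the same place. The measured exchanges there, a step that the two limits leave unreadable from compound 1 to compound 3 and a step that the two limits leave unreadable from compound 2 to compound 3, give no size, so no step beyond the scatter and no direction is expected in this assay here. The expected change is a step that the limit leaves unreadable from compound 3 to compound 4 as an estimate only. For compound 4 the estimate is 5000 nM with an expected range from 1000 nM to 20000 nM in this read-out.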

Compound 4, half-maximal effective concentration: > 1000 nM
Compound 4 was reported as a limit; the forecaster's own chance of this, stated with the estimate: 75%; the middle value does not contradict the limit.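

Compound 4 gives > 1000 nM, which is a limit, so its steps from compound 1, compound 2 and compound 3 cannot be read. The compounds shown leave open whether pyrrolidin-1-yl and 1,3-thiazol-5-yl differ at all in this assay.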